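The source may hold more compounds than are shown below. What is called first, only, known or untested is meant among the compounds shown, and "the series" means these compounds.

Compound 1 `CCn1cc(-c2nc3ccccc3s2)c(=O)c2cc(F)c(N3CCNCC3)cc21` and compound 2 `CCn1cc(-c2nc3ccccc3s2)c(=O)c2cc(F)c(N3CCN(C)CC3)cc21` are built on one core, while compound 3 `CCn1cc(-c2nc3ccc([N+](=O)[O-])cc3[nH]2)c(=O)c2cc(F)c(N3CCNCC3)cc21` and compound 4 `CCn1cc(-c2nc3ccc([N+](=O)[O-])cc3[nH]2)c(=O)c2cc(F)c(N3CCN(C)CC3)cc21` are built on another; how the two cores differ is not broken down here. In a functional assay on A2780 cells (Homo sapiens) for cytotoxicity, read by MTT assay, with a stated time of 48 h (a higher number here means a weaker inhibitor, a lower number a stronger inhibitor), compound 1 gives 11300 nM and compound 2 gives 114000 nM. The change that separates them, (methyl in place of hydrogen on an amine nitrogen in a ring), made a 10-fold higher number from compound 1 to compound 2 (1.00 log units; beyond the scatter). Compound 3 gives 1600 nM, the lowest of the three measured numbers. Compound 4 carries the same change against compound 3, (methyl in place of hydrogen on an amine nitrogen in a ring), at the same place in the ring. Because the same change made a 10-fold higher number from compound 1 to compound 2 (1.00 log units; beyond the scatter), a step of similar size, a 10-fold higher number from compound 3 to compound 4 (1.00 log units; beyond the scatter), is expected here too, resting on that single earlier example. Compound 4 is therefore estimated to give about 16000 nM, most likely between 5000 nM and 50000 nM.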

Compound 4, half-maximal inhibitory concentration: 4700 nM
Compound 4: middle estimate off by 3.4-fold (0.53 log units), on the high side; measured number below the stated range.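

Going from piperazin-1-yl to 4-methylpiperazin-1-yl raised the number on both cores, so the direction of the change held in this assay and the second core gave a 2.9-fold higher number from compound 3 to compound 4 (0.47 log units; beyond the scatter). The direction carried across, but the size did not: the same change on two cores in this assay, a 10-fold higher number (1.00 log units; beyond the scatter) from compound 1 to compound 2 and a 2.9-fold higher number (0.47 log units; beyond the scatter) from compound 3 to compound 4, 3.4-fold (0.54 log units) apart, beyond the scatter of two such steps. Within the data shown here, with only two cores, this does not show which feature of a core sets the size of the step, or what the same change would do on a third core.

The compounds shown leave open whether a larger group on that nitrogen, such as ethyl or a longer chain, would raise the number further. They also leave open how an acetyl group in the same place would behave on either core.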